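Trifluoromethyl in place of chloro on a tolerated urea

The source may hold more compounds than are shown below. What is called first, only, known or untested is meant among the compounds shown, and "the series" means these compounds.

Measured compounds:
compound 1 `O=C(Nc1cccc(-n2cc(-c3ccncc3)c(-c3ccc(Cl)c(O)c3)n2)c1)Nc1ccc(Cl)c(Cl)c1` — > 32500 nM
compound 2 `COc1cc(-c2nn(-c3cccc(NC(=O)c4ccccc4)c3)cc2-c2ccncc2)ccc1Cl` — > 100000 nM

Both compounds were tested in a functional assay on HCT-15 cells (Homo sapiens) for inhibition, read by sulforhodamine B assay, with a stated time of 48 h; a lower number here means that less compound is tolerated, a higher number that more compound is tolerated. For compound 1 the assay reports only a limit, > 32500 nM. For compound 2 the assay likewise reports only a limit, > 100000 nM. Neither value is a number, so compound 1 cannot be placed above or below compound 2; it simply sits at the limit of > 32500 nM in this assay, at which 1 of the 2 values shown sits, while the other value sits at the limit of > 100000 nM in this assay, at which 1 of the 2 values shown sits.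

Compound 3 `O=C(Nc1cccc(-n2cc(-c3ccncc3)c(-c3ccc(Cl)c(O)c3)n2)c1)Nc1ccc(Cl)c(C(F)(F)F)c1` is the untested partner of compound 1. The two differ in one place: trifluoromethyl in place of chloro on an aromatic carbon. Among the compounds with values here, no measured pair with this change exists here, so the size of the step can only be expected, not read off. Given that compound 1 shows only a limit, the step from compound 1 to compound 3 is expected to stay within the scatter, with an estimated change of a step that the limit leaves unreadable from compound 1 to compound 3. Compound 3 is therefore estimated at 40000 nM, within a range from 15000 nM to 100000 nM, and most likely the assay will again report only a limit.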

Compound 3, concentration lethal to 50% of the cells: > 32500 nM
Compound 3: no number, only a limit; the forecaster's own chance of this, stated with the estimate: 70%; the middle value is on the limit's open side.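

Compound 1 and compound 3 each give only a limit, so no step can be read between them: the limit of > 32500 nM in this assay, at which 2 of the 3 values shown sit.

What the compounds shown leave open is whether trifluoromethyl in place of chloro on an aromatic carbon makes any difference in this assay; a measured number for either compound would be needed to tell.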